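The source may report more compounds than this note shows. Statements on the series, on what has been measured and on what is new or still open speak of the compounds shown alone.

Measured compounds:
- compound 1, `CN1CCCN(CCn2ccc3ccc(Cl)cc32)CC1`, which in an assay on HEK293 cells for binding affinity to 5-hydroxytryptamine receptor 7 (Homo sapiens), read by radioligand binding, tested at 1 uM (a lower number here means less inhibition, a higher number more inhibition at the concentration tested (going by the name of the read-out)), gives 85%
- compound 2, `C#Cc1ccc2ccn(CCN3CCCN(C)CC3)c2c1`, which in this assay gives 79%

Compound 2 has the lower of the two numbers, but its nearest neighbour compound 1 is close: the change was a number 6 percentage points lower from compound 1 to compound 2 (within the scatter), so the two compounds cannot be told apart on these data.

Compound 3, `CCc1ccc2ccn(CCN3CCCN(C)CC3)c2c1`, is not yet measured. It differs from compound 2 by ethyl in place of ethynyl on an aromatic carbon.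

Going by the values given here, only one measured step bears on this change, a number 6 percentage points lower from compound 1 to compound 2 (within the scatter), in which one small substituent on an aromatic carbon was exchanged for another without leaving the scatter. By that precedent, a further exchange of a small substituent on an aromatic carbon is expected to give no step beyond the scatter, with the estimated step being a number 2 percentage points lower from compound 2 to compound 3 (within the scatter). Compound 3 is therefore expected to give about 77%, within a range from 62% to 90%.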

Compound 3, a percentage reported as inhibition, at one concentration (the size of the read-out at that concentration, not a potency): 66%
For compound 3 the middle estimate is 11 percentage points above the measured one; the measured number falls inside the stated range.
By their numbers in this assay, from the lowest: compound 3; then compounds 2 and 1 (each within the scatter of the next).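

In this assay this position on the six-membered aromatic ring does respond to the substituent: ethyl in place of ethynyl gives a number 13 percentage points lower from compound 2 to compound 3 (beyond the scatter) and, set against chloro, ethyl gives a number 19 percentage points lower from compound 1 to compound 3 (beyond the scatter) as well. Chloro and ethynyl could not be told apart, so the ethyl compound is the first to stand clear of both, even though ethyl and ethynyl have the same count of heavy atoms and differ by the triple bond that leaves. Nothing available explains this step.

The compounds shown leave open how a methoxy group, a nitrile or a longer chain such as propyl would read at this position. They also leave open whether ethyl in place of ethynyl would give a similar step at another position on the shared core.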